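Adding a Methoxy Group to Compound 2

The source may report more compounds than this note shows. Statements on the series, on what has been measured and on what is new or still open speak of the compounds shown alone.

In a functional assay on MDA-MB-231 cells (Homo sapiens) for antiproliferative activity, read by sulforhodamine B assay, with a stated time of 48 h (on this read-out higher numbers stand for weaker inhibition and lower numbers for stronger inhibition), compound 2 (`COc1ccc2nc(-c3ccc(N/C=C\C(=O)c4ccc(OC)c([N+](=O)[O-])c4)cc3)sc2c1`) gives 17600 nM. Compound 3 (`COc1ccc2nc(-c3ccc(N/C=C\C(=O)c4ccc(OC)c([N+](=O)[O-])c4)c(C)c3)sc2c1`) gives 17600 nM, the same at the digits shown, and compound 1 (`COc1ccc2nc(-c3ccc(N/C=C\C(=O)c4cc(OC)c(OC)c(OC)c4)cc3)sc2c1`) gives 19600 nM. All three numbers lie within the usual scatter of one another, so this small set separates none of them on potency.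

The next candidate is compound 4 (`COc1ccc2nc(-c3ccc(N/C=C\C(=O)c4cc(OC)c(OC)c([N+](=O)[O-])c4)cc3)sc2c1`), which has not yet been measured. It is compound 2 with one change: methoxy in place of hydrogen on an aromatic carbon. In words, this is methoxy in place of hydrogen on an aromatic carbon.

For the measured compounds named here, only one measured step involves a single swap of this general kind. That step, no change at the digits printed from compound 2 to compound 3 (within the scatter), is a methyl in place of hydrogen on an aromatic carbon, and it stays within the scatter. Going by the values given here, it is only a loose guide, since it concerns a different group elsewhere in the molecule, and no measured step shows what a methoxy does here. Even so, nothing measured so far points to a large move in either direction in this assay.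

The expected step is a 1.0-fold higher number from compound 2 to compound 4 (0.01 log units; within the scatter), which would not stand out from the scatter. For compound 4 the estimated value is 18000 nM, with an expected range of 8500 nM to 35000 nM.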

Compound 4, half-maximal inhibitory concentration: 7610 nM
Compound 4: the middle estimate sits 2.4-fold (0.37 log units) above what was measured; the whole stated range lies above it.
By their numbers in this assay, from the lowest: compound 4; then compounds 2, 3 and 1 (each within the scatter of the next).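

In this assay, for the compounds shown here, the added methoxy, ortho to a methoxy group and meta to a nitro group, brings a 2.3-fold lower number from compound 2 to compound 4 (0.36 log units; beyond the scatter) and is the first single change here to move the number beyond the scatter, whereas the methyl elsewhere in the molecule brought no change at the digits printed from compound 2 to compound 3 (within the scatter) and did not. The other neighbour adds a second point about the same ring: swapping one methoxy for a nitro group gives a 2.6-fold lower number from compound 1 to compound 4 (0.41 log units; beyond the scatter) and is also beyond the scatter. Compound 4 therefore has a lower number than both compounds that lie one change away from it on this ring, so the added methoxy and the nitro group each count here, although both steps are modest.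

The compounds shown leave open whether this position specifically needs a methoxy, since a hydroxyl, an amine, a fluorine or a longer chain such as ethoxy could give a similar or a different result in the same place. Nothing available here explains the size or direction of either step.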